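The compounds below may be only part of what the source reports. "The series", "measured", "known", "first", "only" and "open" are said of these compounds alone.

Measured compounds:
compound 1, `C/N=C1\S/C(=C\c2cc(C)n(-c3ccc(F)cc3)c2C)C(=O)N1C`, in a functional assay for agonist activity at sphingosine 1-phosphate receptor 5 (Homo sapiens) (a lower number here means that less compound is needed, a higher number that more compound is needed for the effect), compound 1 gives 652 nM.
compound 2, `CC/N=C1\S/C(=C\c2cc(C)n(Cc3c(F)cccc3F)c2C)C(=O)N1CC`, in this assay compound 2 gives 22 nM.

For the measured compounds named here, of the two numbers known, compound 1 has the higher one; compound 2 gives the lower value, and the gap between them is beyond the usual scatter. Going by the values given here, compound 2 differs from compound 1 in several places at once, so its value shows only that the shared core can reach much lower numbers, not which change carries that.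

Compound 3, `C/N=C1\S/C(=C\c2cc(C)n(-c3ccc(Cl)cc3F)c2C)C(=O)N1C`, keeps everything of compound 1 except the group on the aromatic nitrogen: 4-chloro-2-fluorophenyl in place of 4-fluorophenyl on an aromatic nitrogen. Among the compounds with values here, no pair of measured compounds differing in just one place exists here, so there is no measured step to lean on. The change is small and the expected step of a 1.9-fold lower number from compound 1 to compound 3 (0.27 log units; within the scatter) is toward a somewhat lower number, with wide uncertainty. Compound 3 is therefore estimated at 350 nM, likely between 100 nM and 1200 nM.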

Compound 3, half-maximal effective concentration: 3400 nM
Compound 3: middle estimate off by 9.7-fold (0.99 log units), on the low side; the measured number lies above the stated range.
By their numbers in this assay, from the lowest: compound 2; then compound 1; then compound 3.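

On the aromatic nitrogen of the shared core, 4-chloro-2-fluorophenyl in place of 4-fluorophenyl gives, in this assay, a 5.2-fold higher number from compound 1 to compound 3 (0.72 log units; beyond the scatter), a step beyond the usual scatter. For the compounds shown here, this is the first comparison here between compounds that differ in one place, and it shows that the number responds to a change as small as this on the phenyl ring at this position, with more compound needed for the effect. No measurement shown here accounts for the rise.

The entering group differs from the leaving one by both a chlorine and a second fluorine, and the compounds shown do not tell which of the two carries the step. Also open, going by these compounds, is how an unsubstituted phenyl, a 4-methoxyphenyl or a pyridine ring would behave on this nitrogen.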